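The source may hold more compounds than are shown below. What is called first, only, known or untested is meant among the compounds shown, and "the series" means these compounds.

Working notes on the series, read in an ADME assay on Vero cells (Chlorocebus sabaeus) for cytotoxicity, read by MTT assay, with a stated time of 72 h; on this read-out higher numbers stand for lower toxicity in this test and lower numbers for higher toxicity in this test. Compound 1 `O=c1nc(N2CCN(NCC3CCCCC3)CC2)sc2c([N+](=O)[O-])cc(C(F)(F)F)cc12`, carrying cyclohexyl, gives 29.3 ug/mL. Compound 2 `O=c1nc(N2CCN(NCC3CCCC3)CC2)sc2c([N+](=O)[O-])cc(C(F)(F)F)cc12`, carrying cyclopentyl, gives > 64 ug/mL, which is a limit of the assay and not a number. Compound 3 `O=c1nc(N2CCN(NCc3ccc(OC(F)(F)F)cc3)CC2)sc2c([N+](=O)[O-])cc(C(F)(F)F)cc12`, carrying 4-(trifluoromethoxy)phenyl, gives > 64 ug/mL, again only a limit. Its position is therefore (the limit of > 64 ug/mL in this assay, at which 2 of the 3 values shown sit).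

The next change leads to compound 4 `O=c1nc(N2CCN(NCc3cccc(C(F)(F)F)c3)CC2)sc2c([N+](=O)[O-])cc(C(F)(F)F)cc12`, with 3-(trifluoromethyl)phenyl in place of 4-(trifluoromethoxy)phenyl on a saturated chain carbon bound to an amine nitrogen. Both groups hold one six-membered aromatic ring of carbon only.

The nearest measured evidence is an at least 2.1-fold higher number from compound 1 to compound 3 (0.33 log units; beyond the scatter), where the aromatic group replaces cyclohexyl. The cyclopentyl change gives a step of similar reach, an at least 2.1-fold higher number from compound 1 to compound 2 (0.33 log units; beyond the scatter). The remaining comparison is a step that the two limits leave unreadable from compound 2 to compound 3. Among the measured compounds shown here, no measured step exchanges one aromatic group for another, so no step beyond the scatter is expected in this assay, and a further limit reading is quite likely. The expected change is an at least 1.0-fold lower number from compound 3 to compound 4 (0.02 log units; that floor lies within the scatter), and it can only be read loosely against a limit. For compound 4 the estimated value is 60 ug/mL, with an expected range from 30 ug/mL to 90 ug/mL.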

Compound 4, half-maximal cytotoxic concentration: > 64 ug/mL
Compound 4 gave a limit, no number; the forecaster's own chance of this, stated with the estimate: 65%; middle value at least 1.0-fold (0.02 log units) away from the limit.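

In this assay compound 4 gives > 64 ug/mL, which is a limit of the assay and not a number. This gives a second aromatic group at this place, on a saturated chain carbon bound to an amine nitrogen, and the reading against the cyclohexyl compound is an at least 2.1-fold higher number from compound 1 to compound 4 (0.33 log units; beyond the scatter). Among the compounds shown here, the steps to compound 4 from compound 3 and from compound 2 cannot be read, so exchanging 4-(trifluoromethoxy)phenyl for 3-(trifluoromethyl)phenyl shows only that the new group also reaches the top of the measurable range, and the series now gathers at a single reading: the limit of > 64 ug/mL in this assay, at which 3 of the 4 values shown sit.

Compound 1 remains the only one of the four with a number, so any differences among the cyclopentyl compound and the two aromatic compounds stay hidden, and the compounds shown give no size for them. Also open, from the compounds shown here alone, is whether a benzyl group carrying a carboxylic acid or an amine on its ring, or a longer chain between the ring and the amine nitrogen, would stay at this limit or return a number in this assay.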